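The source may report more compounds than this note shows. Statements on the series, on what has been measured and on what is new or still open speak of the compounds shown alone.

Measured compounds:
compound 1, `COc1ccc(OC)c(CN(C(=O)Nc2ccc(C)cc2)n2cnnc2)c1`, 20900 nM
compound 2, `O=C(NCc1ccccc1)N(Cc1ccccn1)n1cnnc1`, 21200 nM

Both numbers come from a functional assay on DU-145 cells (Homo sapiens) for cytotoxicity, read by MTT assay, with a stated time of 48 h; a higher number here means a weaker inhibitor, a lower number a stronger inhibitor. Compound 2 gives the highest of the two numbers, yet its nearest neighbour, compound 1, sits within the scatter of it, so no order between the two can be read. Among the compounds with values here, no pair among the measured compounds differs in one place only, so no measured step is available to calibrate any single change.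

Compound 3, `Cc1ccc(NC(=O)N(Cc2ccccn2)n2cnnc2)cc1`, is not yet measured. Relative to compound 2 it shows (4-methylphenyl in place of benzyl on an amide-type nitrogen); the two compounds contain the same atoms, joined differently. Within the data shown here, no measured step of this kind exists. Compound 1, which also carries a 4-methylphenyl group, gives 20900 nM, close to compound 2. On that basis the expected step is a 1.2-fold lower number from compound 2 to compound 3 (0.07 log units; within the scatter), that is, none beyond the scatter. For compound 3 the estimate in this assay is 18000 nM, with a range from 8000 nM to 40000 nM.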

Compound 3, half-maximal inhibitory concentration: 21500 nM
Compound 3: the middle estimate sits 1.2-fold (0.08 log units) below what was measured; the range from low to high includes it.
By their numbers in this assay, from the lowest: compounds 1, 2 and 3 (each within the scatter of the next).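

In this assay, within the data shown here, 4-methylphenyl in place of benzyl on the amide-type nitrogen gives a 1.0-fold higher number from compound 2 to compound 3 (0.01 log units; within the scatter), the only single-place step measured. Leaving and entering groups match in heavy atoms, carbon-only aromatic ring, hydrogen-bond donors and acceptors and net charge, but are joined differently, and this rearrangement of the same atoms does not separate the two compounds in this assay. No measurement on hand bears on this result, and the step alone gives no account of it.

Among these compounds, the step covers only two carbon-only aromatic groups with the same atoms, so it does not show whether this nitrogen substituent can move the number beyond the scatter at all. A substituent of different make-up in the same place, such as a carboxylic acid or an amine on the phenyl ring, or a longer chain such as phenethyl, would test this position more widely than the present pair of compounds can.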